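The source may report more compounds than this note shows. Statements on the series, on what has been measured and on what is new or still open speak of the compounds shown alone.

Measured so far in a functional assay on HL-60 cells (Homo sapiens) for cytotoxicity, read by MTT assay, with a stated time of 4 days; a higher number here means a weaker inhibitor, a lower number a stronger inhibitor:

Compound 1 `C=C1C[C@]23C[C@@]1(O)CC[C@@H]2c1cccc(C)c1[C@@H]3Cn1cc(-c2ccccn2)nn1` gives > 20000 nM; this is a limit of the assay, not a number.
Compound 2 `C=C1C[C@]23C[C@@]1(O)CC[C@@H]2c1cccc(C)c1[C@@H]3Cn1cc(-c2ccc(C(F)(F)F)cc2)nn1` gives > 20000 nM; again a limit, not a number.
Compound 3 `C=C1C[C@]23C[C@@]1(O)CC[C@H]2c1ccc(OS(=O)(=O)c2ccc(C)cc2)c(C)c1[C@@H]3Cn1cc(-c2ccc(C(F)(F)F)cc2)nn1` gives > 20000 nM; again a limit, not a number.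

Compound 1 and compound 2 share one core and differ only on the five-membered aromatic ring with 3 nitrogen: pyridin-2-yl in place of 4-(trifluoromethyl)phenyl on an aromatic carbon. The step that the two limits leave unreadable from compound 2 to compound 1 cannot be sized because the limit of > 20000 nM in this assay, at which 3 of the 3 values shown sit, holds both of its ends. Compound 3 carries a different core from compound 2; how the two cores differ is not broken down here.

Compound 4 `C=C1C[C@]23C[C@@]1(O)CC[C@H]2c1ccc(OS(=O)(=O)c2ccc(C)cc2)c(C)c1[C@@H]3Cn1cc(-c2ccccn2)nn1` has not yet been measured. It stands to compound 3 as compound 1 stands to compound 2: pyridin-2-yl in place of 4-(trifluoromethyl)phenyl on an aromatic carbon. The surroundings of the place are described in the same words for both pairs, so the change is the same, made on the core of compound 3 instead of the core of compound 1.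

Nothing measured gives a direction for this change, since the earlier pair sits entirely at the limit of > 20000 nM in this assay, at which 3 of the 3 values shown sit. The expectation for compound 4 therefore rests on compound 3, whose value in this assay is a limit. It also rests on compound 1, whose value is a limit. Compound 4 is expected to return a limit as well, with an estimated value of 40000 nM and a range from 15000 nM to 200000 nM. The step that this estimate means, a step that the limit leaves unreadable from compound 3 to compound 4, is expected to stay unreadable in the same way.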

Compound 4, half-maximal inhibitory concentration: > 20000 nM
Compound 4 ended at the assay's limit (the forecaster's own chance of this, stated with the estimate: 85%); the middle value lies beyond the limit too.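

In this assay compound 4 gives > 20000 nM as a limit and not a number. No step can be read between compound 3 and compound 4, because both values sit at the same limit: the limit of > 20000 nM in this assay, at which 4 of the 4 values shown sit.

The compounds shown leave open whether pyridin-2-yl and 4-(trifluoromethyl)phenyl differ in their effect on cytotoxicity on either core, and whether the two cores differ.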